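A few compounds are considered here, and "the series" means these few. Any claim that something is new, unique, unknown or untested is made for them only; others in the source may bear on it.

Working notes on the series. Compound 1 `Cc1ccc(S(=O)(=O)c2cnc3ccc(Cl)cc3c2N2CCC(C)CC2)cc1C` gives 84% in an assay on isolated protein for displacement of a labelled ligand from metabotropic glutamate receptor 5 (Homo sapiens), with a stated time of 60 min, tested at 1 uM; on this read-out lower numbers stand for less inhibition and higher numbers for more inhibition at the one concentration tested (going by the name of the read-out). Compound 2 `COc1ccc(S(=O)(=O)c2cnc3ccc(Cl)cc3c2N2CCC(C)CC2)cc1OC` gives 61% in this assay. Compound 3 `COc1ccc(S(=O)(=O)c2cnc3cc(Cl)ccc3c2N2CCC(C)CC2)cc1OC` has the same atoms as compound 2 joined differently, and the difference between the two cores is not broken down here; in this assay compound 3 gives 93%, which sits within the usual scatter of the value of compound 1. Between compound 2 and compound 1 the change is 3,4-dimethylphenyl in place of 3,4-dimethoxyphenyl on a sulfonyl sulfur, and the step is a number 23 percentage points higher from compound 2 to compound 1 (beyond the scatter). Compound 4 `Cc1ccc(S(=O)(=O)c2cnc3cc(Cl)ccc3c2N2CCC(C)CC2)cc1C` remains to be measured in this assay. It differs from compound 3 by 3,4-dimethylphenyl in place of 3,4-dimethoxyphenyl on a sulfonyl sulfur, which is the same change at the same place as the earlier one, now on the core of compound 3. The step to compound 4 is expected to be smaller than the earlier one, because the value of compound 3 93% leaves little room above it in a read-out taken at one concentration. The expected step is a number 1 percentage points higher from compound 3 to compound 4 (within the scatter). Compound 4 is estimated at 94%, between 85% and 99%.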

Compound 4, a percentage reported as inhibition, at one concentration (the size of the read-out at that concentration, not a potency): 86%
Compound 4: middle estimate off by 8 percentage points, on the high side; measured number inside the range.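

In this assay, 3,4-dimethylphenyl in place of 3,4-dimethoxyphenyl on a sulfonyl sulfur gives a number 7 percentage points lower from compound 3 to compound 4 (within the scatter), so no readable step appears on the core of compound 3. The change does not carry over from one core to the other as a constant step: the same change on two cores in this assay, a number 23 percentage points higher (beyond the scatter) from compound 2 to compound 1 and a number 7 percentage points lower (within the scatter) from compound 3 to compound 4, 30 percentage points apart, beyond the scatter of two such steps

This rests on a single pair per core, each read at one concentration; it shows that the size of the step depends on the core within these four compounds, but it does not show why, nor how the same pairs would compare as potencies.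

The compounds shown leave open how the two cores would respond to other groups on the sulfonyl sulfur, such as a plain phenyl, a fluorophenyl or a pyridyl group. Also open, from the compounds shown here alone, is whether the gap between the two steps would persist if a nitrile or a trifluoromethyl group took the place of the chlorine on each core.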